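Moving the hydroxyl on a terminal phenyl ring

This account rests on a few compounds, and the source may have more. Where it says the series, first, only, none or still open, it means among the compounds named here.

Compounds measured so far, in a functional assay on HeLa cells (Homo sapiens) for inhibition; on this read-out higher numbers stand for weaker inhibition and lower numbers for stronger inhibition:
Compound 1 `Oc1cccc(-c2cc(-c3ccccc3F)cc(-c3ccccc3O)n2)c1` gives 31100 nM.
Compound 2 `Oc1cccc(-c2cc(-c3ccccc3OC(F)(F)F)cc(-c3ccccc3O)n2)c1` gives 15200 nM.

Among the measured compounds shown here, compound 2 has the lowest of the two numbers in this assay; its nearest neighbour is compound 1, and the only step in the set, a 2.0-fold lower number from compound 1 to compound 2 (0.31 log units; beyond the scatter), separates them. Compound 3 `Oc1ccc(-c2cc(-c3ccccc3OC(F)(F)F)cc(-c3cccc(O)c3)n2)cc1` is not yet measured. It keeps the same atoms as compound 2 but joins them differently: 4-hydroxyphenyl in place of 2-hydroxyphenyl on an aromatic carbon, next to the ring nitrogen of the shared core. For the measured compounds named here, no measured step bears on this change. Going by the values given here, the single step, a 2.0-fold lower number from compound 1 to compound 2 (0.31 log units; beyond the scatter), concerns the trifluoromethoxy in place of fluoro on a different ring, and it says nothing about relocating the hydroxyl from a 2-hydroxyphenyl to a 4-hydroxyphenyl group. With nothing to guide a direction, compound 3 is expected to sit near compound 2, with no step beyond the scatter, as a 1.0-fold lower number from compound 2 to compound 3 (0.01 log units; within the scatter). Compound 3 is therefore estimated at 15000 nM, with a range from 5000 nM to 45000 nM.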

Compound 3, half-maximal inhibitory concentration: 5800 nM
For compound 3 the middle estimate is 2.6-fold (0.41 log units) above the measured one; measured number inside the range.
By their numbers in this assay, from the lowest: compound 3; then compound 2; then compound 1.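

In this assay, the hydroxyl's place on this terminal ring proves to matter: 4-hydroxyphenyl in place of 2-hydroxyphenyl, on the aromatic carbon next to the ring nitrogen, gives a 2.6-fold lower number from compound 2 to compound 3 (0.42 log units; beyond the scatter). The change is modest but beyond the scatter, and it comes with no change in heavy atoms, hydrogen-bond donors or hydrogen-bond acceptors in the group, so this position responds to how the same atoms are joined, which the earlier step on the other ring could not show. Nothing available explains why the number falls with this move.

The compounds shown leave open how a 3-hydroxyphenyl group would read at this position, and whether the same move would give a similar step with fluoro on the other ring. They also do not show whether an amine or a carboxylic acid could stand in place of the hydroxyl.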